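Fluoroalkenyl thiazole thioethers: cytotoxicity working notes

This account rests on a few compounds, and the source may have more. Where it says the series, first, only, none or still open, it means among the compounds named here.

Measured so far:
- compound 1 `CC(c1nccs1)C(C#N)(C#N)CCC(F)=C(F)F`: > 120000 nM
- compound 2 `FC(F)=C(F)CCSc1nccs1`: > 120000 nM

In a functional assay on HepG2 cells (Homo sapiens) for cytotoxicity, read by MTT assay, with a stated time of 48 h (on this read-out lower numbers stand for stronger inhibition and higher numbers for weaker inhibition), compound 1 gives only a limit, > 120000 nM. Compound 2 likewise gives only a limit in this assay, > 120000 nM. Both values sit at the limit of > 120000 nM in this assay, at which 2 of the 2 values shown sit, so compound 2 stands at the limit with no number of its own; nothing orders it against compound 1.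

Compound 3 `FC(F)=C(F)CCSc1ncc(-c2ccncc2)s1` differs from compound 2 by pyridin-4-yl in place of hydrogen on an aromatic carbon. Going by the values given here, no step between measured compounds exists, so no measured step size guides this change, and with both measured compounds at the limit there is no measured potency to move from. Compound 3 is expected near 100000 nM, with a range from 20000 nM to 300000 nM. The estimated step from compound 2 to compound 3 is an at least 1.2-fold lower number from compound 2 to compound 3 (0.07 log units; that floor lies within the scatter), and a limit rather than a number is again quite possible.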

Compound 3, half-maximal inhibitory concentration: > 120000 nM
Compound 3 was reported as a limit (the forecaster's own chance of this, stated with the estimate: 60%); middle value at least 1.2-fold (0.07 log units) away from the limit.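

Compound 2 and compound 3 both stand as limits, so no step can be read from one to the other: the limit of > 120000 nM in this assay, at which 3 of the 3 values shown sit. The compounds shown leave open what pyridin-4-yl in place of hydrogen does, and whether any compound here reaches a measurable cytotoxic potency.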